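The source may report more compounds than this note shows. Statements on the series, on what has been measured and on what is new or still open speak of the compounds shown alone.

Compound 1 `Cc1ccc(/N=C2\C(=O)Nc3ccc(S(=O)(=O)N4CCOCC4)cc32)cc1`: 55900 nM
Compound 2 `O=C1Nc2ccc(S(=O)(=O)N3CCOCC3)cc2/C1=N/c1ccc(O)cc1`: 52700 nM

Both compounds were tested in a functional assay on MCF7 cells (Homo sapiens) for cytotoxicity, read by sulforhodamine B assay, with a stated time of 24 h; on this read-out lower numbers stand for stronger inhibition and higher numbers for weaker inhibition. Within the data shown here, compound 2, at 52700 nM, cannot be told apart from compound 1, as the only measured step shows: a 1.1-fold lower number from compound 1 to compound 2 (0.03 log units; within the scatter). That step put hydroxy in place of methyl on an aromatic carbon.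

The next compound, compound 3 `O=C1Nc2ccc(S(=O)(=O)N3CCOCC3)cc2/C1=N/c1cccc(C(F)(F)F)c1`, carries 3-(trifluoromethyl)phenyl in place of 4-hydroxyphenyl on a double-bonded nitrogen. This swaps the same aromatic group, but also changes the substituent and where it sits, so the measured step is only a loose guide. It gives no direction, and two compounds cannot show a trend. No change beyond the scatter is therefore expected, though with wide uncertainty. The expected step is a 1.2-fold lower number from compound 2 to compound 3 (0.07 log units; within the scatter). The estimated value for compound 3 is 45000 nM, with an expected range from 18000 nM to 110000 nM.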

Compound 3, half-maximal inhibitory concentration: 41100 nM
Compound 3: the middle estimate sits 1.1-fold (0.04 log units) above what was measured; the measured number falls inside the stated range.
By their numbers in this assay, from the lowest: compounds 3, 2 and 1 (each within the scatter of the next).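

Replacing 4-hydroxyphenyl or 4-methylphenyl with 3-(trifluoromethyl)phenyl on the double-bonded nitrogen gives a 1.3-fold lower number from compound 2 to compound 3 (0.11 log units; within the scatter) and a 1.4-fold lower number from compound 1 to compound 3 (0.13 log units; within the scatter) in this assay and so leaves the compounds impossible to tell apart. The earlier pair differed only in the group on one ring carbon, whereas here the entering group has more heavy atoms, no hydrogen-bond donor or acceptor, and its substituent in a different place, yet the numbers still stay within the scatter. No measurement is available to explain this result.

Going by these compounds, whether an amine or a carboxylic acid on this aromatic ring, or a longer chain in its place, would give a number beyond the scatter remains open. The compounds shown also cannot separate the kind of substituent from where it sits on the ring.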